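This account rests on a few compounds, and the source may have more. Where it says the series, first, only, none or still open, it means among the compounds named here.

In a functional assay on the whole organism for inhibition, with Rattus norvegicus as the target (a lower number here means that less compound is needed, a higher number that more compound is needed for the effect), compound 2 `CCCCSc1nsnc1C1CN2CCC[C@H]1C2` gives 0.007 mg/kg, which stands as the lowest of the two numbers reported. Compound 3 `CCCCSc1nsnc1[C@H]1CN2CCC[C@@H]1C2` gives 0.017 mg/kg in this assay. Compound 1 `CCCCSc1nsnc1C1CN2CCC[C@@H]1C2` is reported only as a limit of the assay, > 3 mg/kg. All three compounds share the same atoms and bonds and differ only in how their stereocentres are drawn, and the steps among them are an at least 420-fold lower number from compound 1 to compound 2 (2.63 log units; beyond the scatter), an at least 170-fold lower number from compound 1 to compound 3 (2.24 log units; beyond the scatter) and a 2.4-fold higher number from compound 2 to compound 3 (0.39 log units; beyond the scatter).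

Compound 4 `CCCCCCSc1nsnc1C1CN2CCC[C@H]1C2` keeps the stereo drawing of compound 2 and differs from it in the chain attached to the sulfur: ethyl in place of hydrogen on a saturated chain carbon, four bonds along the chain from a sulfur. None of the three measured steps touches that chain, so none of them bears directly on this change; the measured record offers no guide to the size or direction of its effect. In the absence of such guidance the step expected is a 2.1-fold higher number from compound 2 to compound 4 (0.33 log units; beyond the scatter), small and uncertain in sign. Compound 4 is therefore estimated at 0.015 mg/kg, with a range from 0.003 mg/kg to 0.08 mg/kg.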

Compound 4, dose for half-maximal effect: 0.1 mg/kg
Beside the measured number, compound 4's estimate is 6.7-fold (0.82 log units) below it, outside the stated range (above it).
By their numbers in this assay, from the lowest: compound 2; then compound 3; then compound 4. At a limit, above all of these: compound 1.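

In this assay, the chain on the sulfur proves to be a sensitive place: ethyl in place of hydrogen on a saturated chain carbon, four bonds along the chain from a sulfur, gives a 14-fold higher number from compound 2 to compound 4 (1.15 log units; beyond the scatter) with the stereo drawing held the same. For the compounds shown here, the earlier compounds differed only in how their stereocentres are drawn, so this is the first step to show that the chain alone, on the shared core, can also move the number by a large amount. Nothing in the evidence at hand bears on this chain, and the step stands without an explanation.

On these data alone, whether a pentyl chain on the sulfur would give a number between those of compound 2 and compound 4 remains open, as does the effect of a propyl chain. Also open, as far as these compounds go, is whether the same change would have a similar effect on compound 3.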